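Replacing the piperidin-4-yl group of compound 2

The compounds below may be only part of what the source reports. "The series", "measured", "known", "first", "only" and "open" are said of these compounds alone.

In a physicochemical assay for solubility, read by nephelometry, measured as kinetic solubility, with a stated time of 30 min (on this read-out higher numbers stand for higher solubility and lower numbers for lower solubility), compound 1 (`NCCOc1ccc([C@H]2CC[C@]3(CC2)OOC2(O3)C3CC4CC(C3)CC2C4)cc1`) reads > 100 ug/mL, which is a limit of the assay and not a number. Among the measured compounds shown here, compound 2 (`CC(C)(O)CN1CCC(Oc2ccc([C@H]3CC[C@]4(CC3)OOC3(O4)C4CC5CC(C4)CC3C5)cc2)CC1`) gives 1.6 ug/mL, the only true number so far. Compound 3 (`CC(C)(N)CCOc1ccc([C@H]2CC[C@]3(CC2)OOC2(O3)C3CC4CC(C3)CC2C4)cc1`) differs from compound 2 by 3-amino-3-methylbutyl in place of 1-(2-hydroxy-2-methylpropyl)piperidin-4-yl on an oxygen on an aromatic ring, with 3-amino-3-methylbutyl in place of 1-(2-hydroxy-2-methylpropyl)piperidin-4-yl on an oxygen on an aromatic ring. For the measured compounds named here, one measured step bears on this: an at least 62-fold lower number from compound 1 to compound 2 (1.79 log units; beyond the scatter), large and beyond the scatter, made by the opposite kind of exchange. Like the 2-aminoethyl of compound 1, the entering group has no ring, so most of that step is expected to be recovered in this assay, though a single pair is thin support. A large rise is expected, a 31-fold higher number from compound 2 to compound 3 (1.49 log units; beyond the scatter). Compound 3 is estimated at 50 ug/mL, with an expected range of 12 ug/mL to 100 ug/mL.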

Compound 3, solubility: 50 ug/mL
Estimate against measurement, compound 3: no gap at the digits printed; measured number inside the range.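

At the place on an oxygen on an aromatic ring, a second swap between the 1-(2-hydroxy-2-methylpropyl)piperidin-4-yl group and a chain with no ring gives a large step in this assay, now in the upward direction: a 31-fold higher number from compound 2 to compound 3 (1.49 log units; beyond the scatter). The two chains themselves are barely separated, with 1-amino-1-methylethyl in place of amino giving an at least 2.0-fold lower number from compound 1 to compound 3 (0.30 log units; that floor lies within the scatter), so no real loss can be claimed for that change. The reading of compound 1 is a limit and not a number, and the true size of this step stays unknown because of it: the limit of > 100 ug/mL in this assay, at which 1 of the 3 values shown sits.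

The compounds shown leave open whether the low reading of compound 2 goes with the piperidine ring itself or with the 2-hydroxy-2-methylpropyl group on its nitrogen. A piperidin-4-yl group carrying a free secondary amine would separate the two.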